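The source may hold more compounds than are shown below. What is called first, only, known or untested is meant among the compounds shown, and "the series" means these compounds.

Measured in a functional assay on A549 cells (Homo sapiens) for antiproliferative activity, read by MTT assay, with a stated time of 48 h; a higher number here means a weaker inhibitor, a lower number a stronger inhibitor:
- compound 1 `N#Cc1cccc(Nc2ncnc3cc(NC(=O)/C=C/c4ccccc4)sc23)c1`: 17200 nM
- compound 2 `O=C(/C=C/c1ccccc1)Nc1cc2ncnc(Nc3ccc(F)c(Cl)c3)c2s1`: 6670 nM
- compound 3 `O=C(/C=C/c1ccccc1)Nc1cc2ncnc(Nc3cc(Cl)cc(Cl)c3)c2s1`: 12500 nM

Compound 2 stands at the low end of these three numbers, but the separation is clear on one side only. The nearer comparison is a 1.9-fold higher number from compound 2 to compound 3 (0.27 log units; within the scatter), and the further one is a 2.6-fold lower number from compound 1 to compound 2 (0.41 log units; beyond the scatter).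

Compound 4 `COc1ccc(/C=C/C(=O)Nc2cc3ncnc(Nc4ccc(F)c(Cl)c4)c3s2)cc1` keeps the group on nitrogen of compound 2 and alters the phenyl of the 2-phenylethenyl group: methoxy in place of hydrogen on an aromatic carbon. This makes it a 4-methoxyphenyl, with the methoxy para to a large group.

Among the compounds with values here, no measured step touches this phenyl. All three exchange the aryl group on nitrogen, so they bear on the change only indirectly, as a guide to how far the series moves. The largest, a 2.6-fold lower number from compound 1 to compound 2 (0.41 log units; beyond the scatter), is modest, and the other two stay within the scatter. In this assay, no shift beyond the scatter is therefore expected, and the direction is open. The expected change is small: a 1.1-fold lower number from compound 2 to compound 4 (0.05 log units; within the scatter). The estimated value for compound 4 is 6000 nM, with an expected range of 2200 nM to 16000 nM.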

Compound 4, half-maximal inhibitory concentration: 22700 nM
The estimate for compound 4 lay 3.8-fold (0.58 log units) below the measured number, outside the stated range (above it).
By their numbers in this assay, from the lowest: compounds 2, 3, 1 and 4 (each within the scatter of the next, the first and the last beyond it).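

In this assay, phenyl to 4-methoxyphenyl gives a 3.4-fold higher number from compound 2 to compound 4 (0.53 log units; beyond the scatter) and so shows that the 2-phenylethenyl end of the molecule is not silent. The earlier steps shown here covered only the aryl group on nitrogen, and the methoxy step, though modest, lies beyond the scatter and runs toward weaker inhibition. Nothing available accounts for this shift, which rests on a single pair.

Still open, as far as these compounds go, is whether the shift belongs to methoxy or to any group on this aromatic carbon, which a hydroxyl, a fluorine or a dimethylamino group in the same place would help to separate. Also open, from the compounds shown here alone, is whether it carries over to the 3-cyanophenyl of compound 1 or the 3,5-dichlorophenyl of compound 3.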